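Chloro in Place of Methoxy: What to Expect of Compound 4

The compounds below may be only part of what the source reports. "The series", "measured", "known", "first", "only" and "open" are said of these compounds alone.

Compound 1, `O=S(=O)(Nc1ccc(NS(=O)(=O)c2cccc(Cl)c2Cl)cc1)c1cccc(Cl)c1Cl`, gives in an assay for inhibition of liver carboxylesterase 1 (Homo sapiens), read by spectrophotometry (a higher number here means a weaker inhibitor, a lower number a stronger inhibitor), only a limit, > 100000 nM.
Compound 2, `COc1ccc(S(=O)(=O)Nc2ccc(NS(=O)(=O)c3ccc(F)cc3)cc2)cc1`, gives in this assay only a limit, > 100000 nM.
Compound 3, `O=S(=O)(Nc1ccc(NS(=O)(=O)c2cc(Cl)ccc2Cl)cc1)c1cc(Cl)ccc1Cl`, gives in this assay only a limit, > 100000 nM.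

Compound 2 therefore does not stand at a measured number at all: its result is a limit of the assay, and the same holds for the two companions, as summed up in the limit of > 100000 nM in this assay, at which 3 of the 3 values shown sit. No pair among these three differs in a single place, so no measured step is available to lean on.

Compound 4, `O=S(=O)(Nc1ccc(NS(=O)(=O)c2ccc(Cl)cc2)cc1)c1ccc(F)cc1`, is the nearest relative of compound 2. The two differ as follows: chloro in place of methoxy on an aromatic carbon. With every measured value sitting at the same limit, the expectation for compound 4 is a step of a number no higher from compound 2 to compound 4 (the limit leaves the size open), that is, none beyond the scatter, and most probably another limit rather than a number. Compound 4 is thus estimated at 100000 nM, with a range from 30000 nM to 300000 nM.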

Compound 4, inhibition constant: > 100000 nM
Compound 4 gave a limit, no number; the forecaster's own chance of this, stated with the estimate: 80%; the middle value sits exactly at the limit.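

No new step can be read between compound 2 and compound 4, since each gives only a limit of the assay and not a number: the limit of > 100000 nM in this assay, at which 4 of the 4 values shown sit.

The compounds shown leave open how strongly any of them inhibits, and whether chloro in place of methoxy changes that at all.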